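A few compounds are considered here, and "the series" means these few. Any claim that something is new, unique, unknown or untested is made for them only; others in the source may bear on it.

Compound 1 `CC(C)(C)n1cc2c(n1)C(=O)CC1(CCN(C(=O)c3cc(-c4ccc(Cl)cc4)nc4ccccc34)CC1)O2`: 2330 nM
Compound 2 `CN(C)c1ccc(-c2cc(C(=O)N3CCC4(CC3)CC(=O)c3nn(C(C)(C)C)cc3O4)c3ccccc3n2)cc1`: 1150 nM

In a functional assay on A549 cells (Homo sapiens) for inhibition, read by MTT assay, with a stated time of 72 h (on this read-out higher numbers stand for weaker inhibition and lower numbers for stronger inhibition), compound 2 has the lower number of the two, 1150 nM. Compound 3 `CCOc1cc(C(=O)N2CCC3(CC2)CC(=O)c2nn(C(C)(C)C)cc2O3)c2ccccc2n1` has ethoxy in place of 4-(dimethylamino)phenyl on an aromatic carbon, next to the ring nitrogen: ethoxy in place of 4-(dimethylamino)phenyl on an aromatic carbon. Going by the values given here, only one measured step bears on this: a 2.0-fold lower number from compound 1 to compound 2 (0.31 log units; beyond the scatter). It was modest and altered a group on the ring that now leaves, so no measurement shows what losing that whole ring does. A moderate rise in this assay is expected, and the estimated step is a 2.6-fold higher number from compound 2 to compound 3 (0.42 log units; beyond the scatter). For compound 3 the estimated value is 3000 nM, within an expected range of 1000 nM to 9000 nM.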

Compound 3, half-maximal inhibitory concentration: > 10000 nM
Compound 3: only a limit was reported; the forecaster's own chance of this, stated with the estimate: 10%; middle value at least 3.3-fold (0.52 log units) from the limit.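

Compound 3 gives only a limit in this assay, not a number: the limit of > 10000 nM in this assay, at which 1 of the 3 values shown sits. Even so, both new steps can be read as minimum sizes: an at least 8.6-fold higher number from compound 2 to compound 3 (0.93 log units; beyond the scatter) and an at least 4.2-fold higher number from compound 1 to compound 3 (0.63 log units; beyond the scatter). At this position, then, replacing the whole 4-(dimethylamino)phenyl or 4-chlorophenyl group with ethoxy matters more than the change on that ring, a 2.0-fold lower number from compound 1 to compound 2 (0.31 log units; beyond the scatter). The compounds shown leave open whether an unsubstituted phenyl ring or a small amine here would keep the number low. On these data alone, the actual value of compound 3 also remains unknown.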